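Series notes: phenyl in place of amino on the carbonyl

This account rests on a few compounds, and the source may have more. Where it says the series, first, only, none or still open, it means among the compounds named here.

Compound 2 `N#C/C(=C\N1CCN(C(=O)c2ccco2)C1=S)C(N)=O` gives 19200 nM in a functional assay on RXF 393 cells (Homo sapiens) for inhibition, read by sulforhodamine B assay, with a stated time of 48 h (on this read-out lower numbers stand for stronger inhibition of growth and higher numbers for weaker inhibition of growth), the highest of the two numbers in hand; its nearest neighbour is compound 1 `N#C/C(=C\N1CCN(C(=O)c2ccco2)C1=S)C(=O)Nc1ccc(Cl)cc1`, which in this assay gives 13100 nM. For the measured compounds named here, the one step measured so far, a 1.5-fold higher number from compound 1 to compound 2 (0.17 log units; within the scatter), stays within the scatter. Compound 3 `N#C/C(=C\N1CCN(C(=O)c2ccco2)C1=S)C(=O)c1ccccc1` differs from compound 2 by phenyl in place of amino on a carbonyl carbon. Going by the values given here, no measured pair shows this change; the only step that bears on it is the one at the same carbonyl, where a large aromatic group was exchanged for hydrogen on the amide-type nitrogen, and that step, a 1.5-fold higher number from compound 1 to compound 2 (0.17 log units; within the scatter), moved nothing beyond the scatter. On that basis the expected step in this assay is a 1.4-fold lower number from compound 2 to compound 3 (0.14 log units; within the scatter), no clear direction beyond the scatter. Compound 3 is therefore estimated at 14000 nM in this assay, within a range of 5000 nM to 40000 nM.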

Compound 3, concentration for 50% growth inhibition: 4100 nM
For compound 3 the middle estimate is 3.4-fold (0.53 log units) above the measured one; measured number below the stated range.
By their numbers in this assay, from the lowest: compound 3; then compounds 1 and 2 (each within the scatter of the next).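

The position on the carbonyl carbon responds to what is bonded there directly: in this assay the change from carbamoyl to benzoyl gives a step beyond the scatter (a 4.7-fold lower number from compound 2 to compound 3 (0.67 log units; beyond the scatter)). For the compounds shown here, this is the first change to do so, as the earlier exchange on the amide-type nitrogen stayed within the scatter (a 1.5-fold higher number from compound 1 to compound 2 (0.17 log units; within the scatter)). An aromatic ring alone does not account for the gain, since compound 1 also carries one, held through the amide-type nitrogen, and phenyl on the carbonyl carbon still gives a step beyond the scatter (a 3.2-fold lower number from compound 1 to compound 3 (0.50 log units; beyond the scatter)).

The compounds shown leave open whether 4-chlorophenyl, methyl or a longer alkyl chain set directly on this carbonyl carbon would follow compound 3. No data in hand explain the gain.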